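A Methyl Swap at the Limit of the Assay

This account rests on a few compounds, and the source may have more. Where it says the series, first, only, none or still open, it means among the compounds named here.

Three compounds share one core: compound 1 `OC[C@H]1O[C@@H](n2cnc3c(NCc4ccccc4F)ncnc32)[C@H](O)[C@@H]1O`, compound 2 `OC[C@H]1O[C@@H](n2cnc3c(NCc4cccc(F)c4)ncnc32)[C@H](O)[C@@H]1O` and compound 3 `OC[C@H]1O[C@@H](n2cnc3c(NCc4ccc(Br)cc4)ncnc32)[C@H](O)[C@@H]1O`. In a functional assay on G-361 cells (Homo sapiens) for antiproliferative activity, with a stated time of 72 h (on this read-out lower numbers stand for stronger inhibition and higher numbers for weaker inhibition), compound 1 was recorded as "not determined" (no result reported), so it offers no result. Compound 2 gives > 166000 nM, which is a limit of the assay and not a number. Compound 3 gives > 166000 nM, which is likewise only a limit. Compound 3 therefore stands at the limit of > 166000 nM in this assay, at which 2 of the 3 values shown sit.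

Compound 4 `Cc1cccc(CNc2ncnc3c2ncn3[C@@H]2O[C@H](CO)[C@@H](O)[C@H]2O)c1` carries 3-methylphenyl in place of 4-bromophenyl on a saturated chain carbon bound to a nitrogen on an aromatic ring. Among the compounds with values here, the one measured step that bears on this change is a step that the two limits leave unreadable from compound 2 to compound 3, so it supplies no size to carry over. Little movement is therefore expected in this assay, and another limit is the likeliest report. The estimated step is an at least 1.3-fold lower number from compound 3 to compound 4 (0.14 log units; that floor lies within the scatter), and it rests on a limit rather than a number. Compound 4 is expected at about 120000 nM, with an estimated range of 15000 nM to 200000 nM.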

Compound 4, half-maximal inhibitory concentration: > 166000 nM
Compound 4 was reported as a limit; the forecaster's own chance of this, stated with the estimate: 60%; at least 1.3-fold (0.14 log units) between middle value and limit.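

Compound 4 gives > 166000 nM, which is a limit of the assay and not a number, so its steps from compound 2 and compound 3 cannot be read. The compounds shown leave open how compound 2, compound 3 and compound 4 rank against one another in this assay, and where compound 1 would stand.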